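The compounds below may be only part of what the source reports. "The series", "measured", "known", "first", "only" and "open" are said of these compounds alone.

Compound 1 `CC(=O)N1CCN(c2nc(=O)c3cc(C(F)(F)F)cc([N+](=O)[O-])c3s2)CC1`: 83.9 ug/mL
Compound 2 `Cc1ccc(C(=O)N2CCN(c3nc(=O)c4cc(C(F)(F)F)cc([N+](=O)[O-])c4s3)CC2)cc1`: 6.7 ug/mL
Compound 3 `CCC(C)C(=O)N1CCN(c2nc(=O)c3cc(C(F)(F)F)cc([N+](=O)[O-])c3s2)CC1`: 104 ug/mL

These numbers come from a physicochemical assay for solubility, read by HPLC (a lower number here means a less soluble compound, a higher number a more soluble compound), where compound 2 stands lowest of the three. Compound 4 `O=C(c1cccc(F)c1)N1CCN(c2nc(=O)c3cc(C(F)(F)F)cc([N+](=O)[O-])c3s2)CC1` is not yet measured. It differs from compound 2 in one place: 3-fluorophenyl in place of 4-methylphenyl on a carbonyl carbon. Two large steps bear on this change, a 13-fold lower number from compound 1 to compound 2 (1.10 log units; beyond the scatter) and a 16-fold higher number from compound 2 to compound 3 (1.19 log units; beyond the scatter). Each of them adds or removes an aromatic ring on that carbonyl carbon. Going by the values given here, compound 4 keeps such a ring, as compound 2 does, and no measured step goes from one ring to another. A step beyond the scatter is therefore not expected, so compound 2 at 6.7 ug/mL serves as the anchor. The estimated change is a 1.2-fold higher number from compound 2 to compound 4 (0.08 log units; within the scatter). For compound 4 the expected value is 8 ug/mL, with an estimated range from 3.5 ug/mL to 20 ug/mL.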

Compound 4, solubility: 0.2 ug/mL
The estimate for compound 4 lay 40-fold (1.60 log units) above the measured number; measured number below the stated range.
By their numbers in this assay, from the lowest: compound 4; then compound 2; then compounds 1 and 3 (each within the scatter of the next).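

Until now, every large step at this carbonyl carbon added or removed an aromatic ring, yet in this assay one ring replacing another gives a 34-fold lower number from compound 2 to compound 4 (1.53 log units; beyond the scatter), so the choice of ring also matters here. Putting 3-fluorophenyl in place of the open-chain groups gives a 520-fold lower number from compound 3 to compound 4 (2.72 log units; beyond the scatter) and a 420-fold lower number from compound 1 to compound 4 (2.62 log units; beyond the scatter).

Nothing measured here bears on why this ring change has so large an effect. Still open, on these data alone, is whether the fluorine, its ring position or the lost methyl accounts for the step, and how a ring carrying an amine or a carboxylic acid would read.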